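A Sulfamoyl Group Added to Compound 1

The compounds below may be only part of what the source reports. "The series", "measured", "known", "first", "only" and "open" are said of these compounds alone.

Among the compounds with values here, in a functional assay on TM4 cells (Mus musculus) for cytotoxicity, read by MTT assay, with a stated time of 72 h (on this read-out lower numbers stand for stronger inhibition and higher numbers for weaker inhibition), compound 1 `Nc1nc(Nc2ccccc2)sc1C(=O)c1cccnc1` gives 5500 nM, the only exact number so far. Compound 2 `NC(=O)c1sc(Nc2ccccc2)nc1N` reads > 60000 nM, which is a limit of the assay and not a number. Its structure differs from compound 1 by having amino in place of pyridin-3-yl on a carbonyl carbon. That swap makes a large step, an at least 10-fold higher number from compound 1 to compound 2 (1.03 log units; beyond the scatter), and the limit of > 60000 nM in this assay, at which 1 of the 2 values shown sits, marks where the measurement stops.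

Compound 3 `Nc1nc(Nc2ccc(S(N)(=O)=O)cc2)sc1C(=O)c1cccnc1` keeps that pyridin-3-yl carbonyl and changes the other end of the molecule, with sulfamoyl in place of hydrogen on an aromatic carbon. Within the data shown here, no measured step touches this place. Among the measured compounds shown here, the single step at the carbonyl shows that this assay can respond strongly to a structural change, but it gives no direction for this one. So no step beyond the scatter is expected, though the uncertainty is wide. The estimated step is a 1.4-fold lower number from compound 1 to compound 3 (0.14 log units; within the scatter). Compound 3 is expected to give about 4000 nM. The estimated range for compound 3 runs from 500 nM to 30000 nM.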

Compound 3, half-maximal inhibitory concentration: 13000 nM
The estimate for compound 3 lay 3.3-fold (0.51 log units) below the measured number; measured number inside the range.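

With this change, the far end of the molecule also proves able to move the read-out: in this assay, sulfamoyl in place of hydrogen on an aromatic carbon, para to a large group, gives a 2.4-fold higher number from compound 1 to compound 3 (0.37 log units; beyond the scatter). The step is modest, and it points towards weaker inhibition, yet compound 3 still gives a measured number of 13000 nM, so this position accepts a group of 4 heavy atoms without the exact read-out being lost. Compound 2, changed at the carbonyl instead, remains a limit of the assay and not a number: the limit of > 60000 nM in this assay, at which 1 of the 3 values shown sits.

A single pair gives the direction for one group at one place, so it cannot separate the role of the sulfur and its two oxygens from that of the terminal nitrogen, nor say whether any other group would shift the number the same way. A carboxylic acid or a simple amine on the same aromatic carbon, or sulfamoyl at another place on that ring, would be needed to tell whether the rise belongs to sulfamoyl or to substitution at this position in general.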